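Removing the 4-fluorophenyl from compound 1

This account rests on a few compounds, and the source may have more. Where it says the series, first, only, none or still open, it means among the compounds named here.

Measured compounds:
- compound 1 `CN(C)CCCCCSC1=Nc2ccccc2C(CC(=O)NCc2ccccc2)N1c1ccc(-c2ccc(F)cc2)cc1`: 9060 nM
- compound 2 `O=C(CC1c2ccccc2N=C(SCCCCCN2CCCC2)N1c1ccccc1)NCc1ccc(F)cc1`: 664000 nM
- compound 3 `O=C(CC1c2ccccc2N=C(SCCCCCN2CCCC2)N1c1ccc(-c2ccc(F)cc2)cc1)NCc1ccc(F)cc1`: 19800 nM

In an assay on cells for inhibition of Voltage-dependent T-type calcium channel subunit alpha-1I (Homo sapiens), read by patch clamp (a lower number here means a stronger inhibitor, a higher number a weaker inhibitor), compound 1 gives the lowest of the three numbers. The nearest is compound 3, and compound 2 is the furthest. Among the compounds with values here, the only one-place step among the measured compounds is a 34-fold lower number from compound 2 to compound 3 (1.53 log units; beyond the scatter), where 4-fluorophenyl replaces hydrogen on an aromatic carbon.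

Compound 4 `CN(C)CCCCCSC1=Nc2ccccc2C(CC(=O)NCc2ccccc2)N1c1ccccc1` is not yet measured. It differs from compound 1 in a single place: hydrogen in place of 4-fluorophenyl on an aromatic carbon. This is the reverse of the change between compound 2 and compound 3, so that step bears directly on it. It was large, with the fluorophenyl-bearing compound 3 showing the much lower number. For compound 4, which loses the fluorophenyl, a large step in the opposite direction is therefore expected in this assay, that is, a much higher number than compound 1.

Taking the size of the measured step as a guide, compound 4 is expected to give 270000 nM, with a range from 60000 nM to 1000000 nM. The step expected from compound 1 to compound 4 is a 30-fold higher number from compound 1 to compound 4 (1.47 log units; beyond the scatter), because of the reversed a 34-fold lower number from compound 2 to compound 3 (1.53 log units; beyond the scatter).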

Compound 4, half-maximal inhibitory concentration: 3200 nM
Compound 4: middle estimate off by 84-fold (1.93 log units), on the high side, outside the stated range (below it).
By their numbers in this assay, from the lowest: compound 4; then compound 1; then compound 3; then compound 2.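

In this assay, the 4-fluorophenyl is not a general gain at this aromatic carbon: hydrogen in its place gives a 2.8-fold lower number from compound 1 to compound 4 (0.45 log units; beyond the scatter), so the modest step favours the smaller substituent on this core. The earlier step suggested that this group was a strong driver of inhibition, but its effect changes direction with the rest of the molecule: the same change on two cores in this assay, a 34-fold lower number (1.53 log units; beyond the scatter) from compound 2 to compound 3 and a 2.8-fold higher number (0.45 log units; beyond the scatter) from compound 4 to compound 1, 95-fold (1.98 log units) apart, beyond the scatter of two such steps. The contribution of this position therefore cannot be carried from one pair of compounds to the other, and each pair has to be read on its own core.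

The two pairs differ from each other in two places, the amine at the end of the chain and the fluorine on the benzyl group, and the compounds shown do not separate which of these, or whether both together, reverses the step. Also open, from the compounds shown here alone, is whether the trend on the core of compound 1 holds for other substituents at this aromatic carbon, such as methyl or methoxy, and whether a morpholine at the chain end would pair with the 4-fluorophenyl as the pyrrolidine does.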